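Inverting Two Ring Stereocentres in a Cyclic Peroxide Acid

The source may report more compounds than this note shows. Statements on the series, on what has been measured and on what is new or still open speak of the compounds shown alone.

Measured compounds:
Compound 1 `CC(=O)CC/C=C(\C)CCC1=C(C)CCCC1(C)C` gives > 15000 nM in a functional assay on NCI-H23 cells (Homo sapiens) for inhibition; a higher number here means a weaker inhibitor of growth, a lower number a stronger inhibitor of growth.
Compound 2 `C=C1CCCC(C)(C)C1CC[C@]1(C)CC[C@@H]([C@@H](C)C(=O)O)OO1` gives > 10000 nM in this assay.
Compound 3 `C=C1CCC[C@H]2[C@](C)(CC[C@]3(C)CC[C@@H]([C@@H](C)C(=O)O)OO3)[C@@H](C)CC[C@]12C` gives 1000 nM in this assay.

The value for compound 1 is a limit of this assay, not a number. The value for compound 2 is likewise a limit of this assay and not a number (the limit of > 10000 nM in this assay, at which 1 of the 3 values shown sits). Only compound 3 has a measured number, so compound 2 stands among the two weakest entries shown, without a figure that would rank it against compound 1 (the limit of > 15000 nM in this assay, at which 1 of the 3 values shown sits).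

Compound 4 `C=C1CCCC(C)(C)C1CC[C@@]1(C)CC[C@H]([C@@H](C)C(=O)O)OO1` shares every atom and bond with compound 2; the difference lies purely in stereochemistry (the two compounds have the same atoms and bonds; at least one stereo element is drawn with a configuration in one of them and without one in the other: 2 of 4 stereo elements differ; a stereocentre at a saturated ring carbon is drawn R in compound 2 and S in compound 4; a stereocentre at a saturated ring carbon is drawn S in compound 2 and R in compound 4). Within the data shown here, no step between measured compounds is available here, so the size of the effect of such an inversion cannot be read from the data. With compound 2 at a limit, a step in this assay from compound 2 to compound 4 of any size beyond the scatter would have to be toward stronger inhibition to become visible at all, and the evidence offers no ground to predict that.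

Compound 4 is therefore expected to sit near 10000 nM, with a range of 2500 nM to 30000 nM, and the expected step from compound 2 is a number no higher from compound 2 to compound 4 (the limit leaves the size open).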

Compound 4, concentration for 50% growth inhibition: 7610 nM
The estimate for compound 4 lay 1.3-fold (0.12 log units) above the measured number; the measured number falls inside the stated range.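

Compound 2 gives > 10000 nM in this assay, which is a limit of the assay and not a number. With the two ring stereocentres inverted, the peroxide acid now has a measured value, and the change reads as an at least 1.3-fold lower number from compound 2 to compound 4 (0.11 log units; that floor lies within the scatter), so this inversion shows no change beyond the scatter, although the true step could be larger and only its floor is known. One caution applies to reading this pair as a clean swap of configuration: the fact that one of compounds 2 and 4 is drawn with a defined configuration and the other without, at the place where they differ

The compounds shown leave open the real size of the step, as compound 2 has no number to set against compound 4, and whether the same inversion would act in the same way on the core of compound 3. They also leave open how a methyl ester in place of the carboxylic acid would affect growth inhibition under either configuration of the peroxide ring.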